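The source may hold more compounds than are shown below. What is called first, only, known or untested is meant among the compounds shown, and "the series" means these compounds.

In a functional assay on SW-620 cells (Homo sapiens) for inhibition, read by sulforhodamine B assay, with a stated time of 48 h (a lower number here means a stronger inhibitor of growth, a higher number a weaker inhibitor of growth), the compounds share one core and differ in the aryl group on a carbon with a double bond to nitrogen. Compound 1 (`O=C(Cc1csc2nc(-c3ccc(Br)cc3)cn12)N/N=C/c1ccccc1O`) gives 17400 nM. Compound 2 (`O=C(Cc1csc2nc(-c3ccc(Br)cc3)cn12)N/N=C/c1ccc(O)cc1`) reports only a limit, > 100000 nM. Compound 3 (`COc1cccc(OC)c1/C=N/NC(=O)Cc1csc2nc(-c3ccc(Br)cc3)cn12`) gives 49000 nM, the higher of the two actual numbers, and its nearest neighbour is compound 1. The measured steps at this place are a 2.8-fold higher number from compound 1 to compound 3 (0.45 log units; beyond the scatter), an at least 5.7-fold higher number from compound 1 to compound 2 (0.75 log units; beyond the scatter) and an at least 2.0-fold lower number from compound 2 to compound 3 (0.30 log units; that floor lies within the scatter).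

Compound 4 (`O=C(Cc1csc2nc(-c3ccc(Br)cc3)cn12)N/N=C/c1ccc(Cl)cc1Cl`) follows, with 2,4-dichlorophenyl in place of 2,6-dimethoxyphenyl on a carbon with a double bond to nitrogen. Within the data shown here, no measured step contains the entering group, so these steps bear on size only. Among the measured compounds shown here, the one exact step among them, a 2.8-fold higher number from compound 1 to compound 3 (0.45 log units; beyond the scatter), is modest and sets the scale. In this assay, a change beyond the scatter is therefore not expected, with only a slight lean towards a lower number. The step expected for compound 4 is a 1.6-fold lower number from compound 3 to compound 4 (0.21 log units; within the scatter). The estimate for compound 4 is 30000 nM, with an expected range from 9000 nM to 95000 nM.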

Compound 4, concentration for total growth inhibition: 60300 nM
Compound 4: the middle estimate sits 2.0-fold (0.30 log units) below what was measured; low and high end bracket the measured number.
By their numbers in this assay, from the lowest: compound 1; then compounds 3 and 4 (each within the scatter of the next). At a limit, above all of these: compound 2.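

In this assay, the step for 2,4-dichlorophenyl in place of 2,6-dimethoxyphenyl is a 1.2-fold higher number from compound 3 to compound 4 (0.09 log units; within the scatter), so these two groups cannot be told apart on this carbon. Against the new group, 2-hydroxyphenyl keeps its lead, with a 3.5-fold higher number from compound 1 to compound 4 (0.54 log units; beyond the scatter), although compound 2 also carries a hydroxyl group and goes against any pattern resting on the hydroxyl alone. The remaining step is an at least 1.6-fold lower number from compound 2 to compound 4 (0.21 log units; that floor lies within the scatter), and it gives only a floor. The value of compound 2 is only a limit: the limit of > 100000 nM in this assay, at which 1 of the 4 values shown sits.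

On these data alone, whether an aminophenyl group would match 2-hydroxyphenyl on this carbon remains open. So does the effect of a carboxylic acid on the aryl ring, or of a longer chain in place of the aryl group.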